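Swapping the pyrimidinyl group of compound 1 for a dimethylpyridinyl

The compounds below may be only part of what the source reports. "The series", "measured", "known", "first", "only" and "open" are said of these compounds alone.

The compounds measured so far, with their values:
compound 1, `Cc1nn(-c2nc(-c3ccc(Cl)c(Cl)c3)c(SC(C)C)s2)c(C(=O)O)c1-c1cncnc1`: 22000 nM
compound 2, `Cc1cc(Cl)cc(-c2c(C)nn(-c3nc(-c4ccc(Cl)c(Cl)c4)c(SC(C)C)s3)c2C(=O)O)c1`: 663 nM
compound 3, `Cc1nn(-c2nc(-c3ccc(Cl)c(Cl)c3)c(SC(C)C)s2)c(C(=O)O)c1-c1cccc(C(F)(F)F)c1`: 22000 nM

In a functional assay on BJAB cells (Homo sapiens) for antiproliferative activity, with a stated time of 4 days (a higher number here means that more compound is needed for the effect, a lower number that less compound is needed), compound 1 gives 22000 nM. It stands level with compound 3 at the digits recorded, and together these two hold the highest numbers of the three, meaning the most compound is needed. Compound 2 is the furthest from compound 1, with a 33-fold lower number from compound 1 to compound 2 (1.52 log units; beyond the scatter), a step well beyond the scatter. Compound 3 shows no change at the digits printed from compound 1 to compound 3 (within the scatter).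

Compound 4 is `Cc1cc(-c2c(C)nn(-c3nc(-c4ccc(Cl)c(Cl)c4)c(SC(C)C)s3)c2C(=O)O)cc(C)n1`. Relative to compound 1 the difference is 2,6-dimethylpyridin-4-yl in place of pyrimidin-5-yl on an aromatic carbon. The ring that enters carries two methyl groups and keeps one ring nitrogen, so it sits somewhere between the pyrimidin-5-yl of compound 1 and the substituted phenyl rings of compound 2 and compound 3.

The steps from compound 1 to compound 2 and from compound 1 to compound 3 bear on this change. One was large and toward a lower number, the other showed no change, so the two do not point the same way. The expected step is therefore a moderate move toward a lower number, a 2.8-fold lower number from compound 1 to compound 4 (0.44 log units; beyond the scatter). Compound 4 is thus estimated at 8000 nM, with a range from 1500 nM to 30000 nM.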

Compound 4, half-maximal effective concentration: 580 nM
Beside the measured number, compound 4's estimate is 14-fold (1.14 log units) above it, outside the stated range (below it).
By their numbers in this assay, from the lowest: compounds 4 and 2 (each within the scatter of the next); then compounds 1 and 3 (each within the scatter of the next).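

In this assay, a ring with a nitrogen can sit at this position on the pyrazole-free shared core without the high number of compound 1, as the 2,6-dimethylpyridin-4-yl group gives a 38-fold lower number from compound 1 to compound 4 (1.58 log units; beyond the scatter) and a 38-fold lower number from compound 3 to compound 4 (1.58 log units; beyond the scatter), while a 1.1-fold lower number from compound 2 to compound 4 (0.06 log units; within the scatter) leaves it level with the 3-chloro-5-methylphenyl group.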